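A few compounds are considered here, and "the series" means these few. Any claim that something is new, unique, unknown or untested is made for them only; others in the source may bear on it.

Notes on the series. The shared core carries a triple-bonded arm; compound 1 `COC(=O)c1sc2cc(C#Cc3ccccc3OC)cnc2c1N` bears 2-methoxyphenyl there and compound 2 `COC(=O)c1sc2cc(C#Cc3cccnc3)cnc2c1N` bears pyridin-3-yl. In a functional assay on A375-C5 cells (Homo sapiens) for inhibition, read by sulforhodamine B assay, with a stated time of 48 h (a higher number here means a weaker inhibitor of growth, a lower number a stronger inhibitor of growth), compound 1 reaches only a limit of the assay, > 47300 nM. In this assay compound 2 likewise reaches only a limit, > 150000 nM. The step that the two limits leave unreadable from compound 1 to compound 2 cannot be read. Compound 2 stands at a limit, (the limit of > 150000 nM in this assay, at which 1 of the 2 values shown sits). Compound 1 stands at a limit too, (the limit of > 47300 nM in this assay, at which 1 of the 2 values shown sits). Compound 3 `COC(=O)c1sc2cc(C#Cc3ccsc3)cnc2c1N` is the next change: thiophen-3-yl in place of pyridin-3-yl on a triple-bonded carbon. Going by the values given here, no measured step bears directly on this exchange, and the single measured step, a step that the two limits leave unreadable from compound 1 to compound 2, is itself unreadable. Nothing among the shown numbers points to a gain in this assay; both rings tried so far on the triple-bonded carbon left a limit. Compound 3 is therefore expected to sit at 120000 nM, within 25000 nM to 500000 nM, most likely as a limit once more. The step of an at least 1.2-fold lower number from compound 2 to compound 3 (0.09 log units; that floor lies within the scatter) is expected to be none beyond the scatter.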

Compound 3, concentration for 50% growth inhibition: 29600 nM
Estimate against measurement, compound 3: 4.1-fold (0.61 log units) above; the range from low to high includes it.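

Compound 3, with thiophen-3-yl on the triple-bonded carbon, is the first compound shown to give a number rather than a limit in this assay, at 29600 nM. Exchanging pyridin-3-yl for thiophen-3-yl gives an at least 5.0-fold lower number from compound 2 to compound 3 (0.70 log units; beyond the scatter), so the identity of the ring at this position can matter, and the figure is only a floor set by the limit of the starting compound: the limit of > 150000 nM in this assay, at which 1 of the 3 values shown sits. The comparison with the 2-methoxyphenyl arm is less informative, giving only an at least 1.5-fold lower number from compound 1 to compound 3 (0.20 log units; that floor lies within the scatter), so no order between those two arms can be claimed from a floor tied to this limit: the limit of > 47300 nM in this assay, at which 1 of the 3 values shown sits.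

Thiophen-3-yl differs from pyridin-3-yl in both ring size and hetero atom, so the compounds shown do not separate the two, and the step between compound 1 and compound 2 cannot be read. From the compounds shown here alone, whether furan-3-yl or unsubstituted phenyl on the triple-bonded carbon would also give a number in this assay remains open, as does the result of a carboxylic acid in place of the methyl ester of the shared core.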